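Naphthalen-1-yl in place of phenyl on the shared core

The compounds below may be only part of what the source reports. "The series", "measured", "known", "first", "only" and "open" are said of these compounds alone.

In a functional assay on MDA-MB-231 cells (Homo sapiens) for inhibition, read by MTT assay, with a stated time of 48 h (on this read-out lower numbers stand for stronger inhibition and higher numbers for weaker inhibition), compound 3 (`COc1cc(-c2cc(-c3ccccc3)nc(-c3ccccc3)n2)cc(OC)c1OC`) gives 5870 nM as the higher of the two exact numbers in this small set. Compound 2 (`COc1cc(-c2cc(-c3cccc(O)c3)nc(-c3ccccc3)n2)cc(OC)c1OC`) gives 1990 nM as the other one. Compound 1 (`COc1cc(-c2cc(-c3ccc(Cl)cc3)nc(-c3ccccc3)n2)cc(OC)c1OC`) gives > 25000 nM as its reading, which is a limit and not a number.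

Compound 4 (`COc1cc(-c2cc(-c3cccc4ccccc34)nc(-c3ccccc3)n2)cc(OC)c1OC`) carries naphthalen-1-yl in place of phenyl on an aromatic carbon. The measured steps on the corresponding aryl group point in both directions. They are an at least 4.2-fold lower number from compound 1 to compound 3 (0.62 log units; beyond the scatter) on losing chloro and a 2.9-fold higher number from compound 2 to compound 3 (0.47 log units; beyond the scatter) on losing hydroxy, while an at least 12-fold lower number from compound 1 to compound 2 (1.09 log units; beyond the scatter) is the large one. Compound 4 has no hydroxy, so the gain of compound 2 is not expected to carry over, and its all-carbon group is read as closer to the chloro case of compound 1. A modest weakening is therefore expected, estimated as a 2.2-fold higher number from compound 3 to compound 4 (0.35 log units; beyond the scatter) in this assay for now. For compound 4 the estimated value is 13000 nM with an expected range from 3500 nM to 25000 nM in this estimate.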

Compound 4, half-maximal inhibitory concentration: 3240 nM
Beside the measured number, compound 4's estimate is 4.0-fold (0.60 log units) above it; measured number outside the range, below it.
By their numbers in this assay, from the lowest: compounds 2, 4 and 3 (each within the scatter of the next, the first and the last beyond it). At a limit, above all of these: compound 1.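

At this position, naphthalen-1-yl and the single phenyl ring read alike in this assay, with a 1.8-fold lower number from compound 3 to compound 4 (0.26 log units; within the scatter). Among these compounds, the second aromatic ring, which adds no hydrogen-bond donor, also leaves the reading level with that of the 3-hydroxyphenyl group, with a 1.6-fold higher number from compound 2 to compound 4 (0.21 log units; within the scatter), so a hydroxy group is not the only route to a reading in this range, and the all-carbon group does not follow the 4-chlorophenyl case, with an at least 7.7-fold lower number from compound 1 to compound 4 (0.88 log units; beyond the scatter). That last step is open-ended, since compound 1 stands at a limit and not at a number: the limit of > 25000 nM in this assay, at which 1 of the 4 values shown sits.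

The compounds shown leave open how naphthalen-2-yl, or a phenyl group bearing an amine or a carboxylic acid, would read at this position. They also leave open whether the same changes would hold with another group in place of the remaining phenyl on the shared core.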